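This account rests on a few compounds, and the source may have more. Where it says the series, first, only, none or still open, it means among the compounds named here.

Measured so far:
Compound 1 `ClCc1ccc(Cn2cnc3c(Cl)ncnc32)cc1` gives > 100000 nM in a functional assay on SK-MEL-28 cells (Homo sapiens) for cytotoxicity, read by sulforhodamine B assay, with a stated time of 48 h (a higher number here means that more compound is tolerated, a lower number that less compound is tolerated), which is a limit of the assay and not a number.
Compound 2 `ClCc1cccc(Cn2cnc3c(Cl)nc(Cl)nc32)c1` gives > 100000 nM in this assay, likewise only a limit.
Compound 3 `Nc1nc(Cl)c2ncn(Cc3ccccc3CCl)c2n1` gives 74100 nM in this assay.

Going by the values given here, compound 3 therefore stands as the only compound with an actual number; the two other values sit at the limit of > 100000 nM in this assay, at which 2 of the 3 values shown sit. Compound 4 `ClCc1ccccc1Cn1cnc2c(Cl)ncnc21` differs from compound 3 by hydrogen in place of amino on an aromatic carbon. Among the compounds with values here, no step between measured compounds exists to gauge this change. Since compound 3 already lies close to the limit of > 100000 nM in this assay, at which 2 of the 3 values shown sit, the step of a 1.6-fold higher number from compound 3 to compound 4 (0.21 log units; within the scatter) is expected to be modest and to run toward a higher number, with a fair chance that only a limit is reported. Compound 4 is expected to give 120000 nM, within 50000 nM to 300000 nM.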

Compound 4, concentration lethal to 50% of the cells: 24600 nM
Compound 4: the middle estimate sits 4.9-fold (0.69 log units) above what was measured; the measured number lies below the stated range.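

Hydrogen in place of amino, on an aromatic carbon between two ring nitrogen atoms, gives in this assay a 3.0-fold lower number from compound 3 to compound 4 (0.48 log units; beyond the scatter), so the amino group is not required for the cytotoxicity seen here. The earlier compounds offered no step to read, and this first one runs away from the limit rather than toward it: the limit of > 100000 nM in this assay, at which 2 of the 4 values shown sit.

The compounds shown leave open how a methylamino or a methoxy group on this carbon would read. They also leave open whether the same change gives a step of similar size on the core of another compound.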